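Working notes: exchanging the amine side chain

The source may hold more compounds than are shown below. What is called first, only, known or untested is meant among the compounds shown, and "the series" means these compounds.

compound 1 `CN1CCC=C(c2ccc(CN(C)Cc3ccc(Cl)cc3)cc2)C1`: 2140 nM
compound 2 `CC(C)CCN(C)Cc1ccc(C2CCCN(C)C2)cc1`: "not determined" (no result reported)
compound 3 `CC(C)CCCN(C)Cc1ccc(C2CCCN(C)C2)cc1`: "not determined" (no result reported)

All three compounds were taken into a functional assay on HL-60 cells (Homo sapiens) for inhibition (a higher number here means a weaker inhibitor, a lower number a stronger inhibitor), but only compound 1 has a number there, at 2140 nM. Compound 2 stands at "not determined" (no result reported). Compound 3 stands at "not determined" (no result reported), so it has no place on the scale and offers no number to step from.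

Compound 4 `CN(Cc1ccc(Cl)cc1)Cc1ccc(C2CCCN(C)C2)cc1` has yet to be measured. The change 4-chlorophenyl in place of isopentyl on a saturated chain carbon bound to an amine nitrogen puts 4-chlorophenyl in place of isopentyl on a saturated chain carbon bound to an amine nitrogen. Seen another way, 4-methylpentyl gives way to 4-chlorobenzyl.

With no starting value, no direction or size can be assigned to this step in this assay. Within the data shown here, the only anchor is compound 1 at 2140 nM, and no departure from it beyond the scatter is expected, although a single value gives weak support. For compound 4 the estimated value is 2000 nM, with an expected range of 600 nM to 7000 nM.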

Compound 4, half-maximal inhibitory concentration: 1290 nM
For compound 4 the middle estimate is 1.6-fold (0.19 log units) above the measured one; low and high end bracket the measured number.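

In this assay the 4-chlorobenzyl side chain now has a value on two versions of the core: the exchange of one six-membered non-aromatic ring for another on the aromatic carbon gives a 1.7-fold lower number from compound 1 to compound 4 (0.22 log units; within the scatter) and so does not separate the two compounds. The step from compound 3 to compound 4 cannot be read, so the exchange of 4-methylpentyl for 4-chlorobenzyl still has no direction or size. No measurement available here offers an explanation for this result.

Open, on these data alone, is how a benzyl group without the chlorine, or a 4-fluorobenzyl group, would compare with 4-chlorobenzyl on this amine nitrogen. Also open, as far as these compounds go, is how a side chain carrying a carboxylic acid would read on the same core.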